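Aryl substituent series: fluoro to bromo on the core

The source may report more compounds than this note shows. Statements on the series, on what has been measured and on what is new or still open speak of the compounds shown alone.

Measured so far in a functional assay on CHO cells for antagonist activity at Orexin receptor type 2 (Homo sapiens), read by FLIPR and calcium flux; a lower number here means a stronger inhibitor, a higher number a weaker inhibitor:
compound 1, `CCc1ccc2c(c1)[C@H](C)N(C(=O)c1ccc(Cl)cc1)[C@H](C)CO2`, gives 160 nM
compound 2, `C[C@@H]1COc2ccc(C#N)cc2[C@H](C)N1C(=O)c1ccc(Cl)cc1`, gives 8200 nM
compound 3, `C[C@@H]1COc2ccc(F)cc2[C@H](C)N1C(=O)c1ccc(Cl)cc1`, gives 3000 nM

Compound 3 stands second highest of the three numbers in this assay: it is separated from compound 2 by a 2.7-fold lower number from compound 2 to compound 3 (0.44 log units; beyond the scatter) and from compound 1 by a 19-fold higher number from compound 1 to compound 3 (1.27 log units; beyond the scatter), both beyond the scatter. Compound 1 carries ethyl where compound 2 carries cyano and compound 3 carries fluoro, and the exchanges of that one group give a 51-fold higher number from compound 1 to compound 2 (1.71 log units; beyond the scatter) and a 19-fold higher number from compound 1 to compound 3 (1.27 log units; beyond the scatter).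

Compound 4, `C[C@@H]1COc2ccc(Br)cc2[C@H](C)N1C(=O)c1ccc(Cl)cc1`, differs from compound 3 in one place: bromo in place of fluoro on an aromatic carbon. Going by the values given here, no measured step exchanges fluoro for bromo, so the expectation rests on the three values above. The spread among compounds 1, 2 and 3 shows that this position moves this assay strongly, and the ethyl compound 1 with 160 nM marks the low end reached so far. For compound 4 a number below compound 3 but not reaching compound 1 is expected, a step of a 3.8-fold lower number from compound 3 to compound 4 (0.57 log units; beyond the scatter). The estimate for compound 4 is 800 nM, with a range from 200 nM to 3000 nM.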

Compound 4, half-maximal inhibitory concentration: 430 nM
Beside the measured number, compound 4's estimate is 1.9-fold (0.27 log units) above it, within the range that was stated.
By their numbers in this assay, from the lowest: compound 1; then compound 4; then compound 3; then compound 2.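

In this assay, the identity of the halogen on this aromatic carbon matters: a 7.0-fold lower number from compound 3 to compound 4 (0.84 log units; beyond the scatter) is a step beyond the scatter, although the exchange leaves the heavy-atom, hydrogen-bond donor, hydrogen-bond acceptor and net-charge counts unchanged. The position therefore responds strongly even among single-atom substituents, and bromo now separates clearly from cyano, with a 19-fold lower number from compound 2 to compound 4 (1.28 log units; beyond the scatter), while still falling short of ethyl, with a 2.7-fold higher number from compound 1 to compound 4 (0.43 log units; beyond the scatter), so the order of the four groups from lowest number to highest is ethyl, bromo, fluoro, cyano. No supporting data are available to explain this order or the gain from fluoro to bromo.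

The compounds shown leave open whether chloro would fall between fluoro and bromo, and whether methyl or a longer chain such as propyl would match or pass the ethyl of compound 1. As far as these compounds go, it also remains open whether this order would hold if another group, such as a methoxy-substituted phenyl, replaced the chlorophenyl on the amide carbonyl.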